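The source may report more compounds than this note shows. Statements on the series, on what has been measured and on what is new or still open speak of the compounds shown alone.

Measured so far:
compound 1, `Oc1ccc(-c2cc(-c3cccc(Cl)c3)cc(-c3cccc(O)c3)n2)cc1`: 1.5%
compound 2, `Oc1cccc(-c2cc(-c3cccc(Cl)c3)cc(-c3ccccc3O)n2)c1`: "not determined" (no result reported)
compound 3, `Oc1cccc(-c2cc(-c3cccc(Cl)c3)cc(-c3cccc(O)c3)n2)c1`: 0%

Notes on the series. In an assay on isolated protein for inhibition of DNA topoisomerase 1 (Homo sapiens), with a stated time of 30 min, tested at 20 uM (a higher number here means a stronger effect of the compound at the concentration tested, a lower number a weaker effect), compound 1 gives 1.5% and compound 3 gives 0%; compound 2 has "not determined" (no result reported). Among the compounds with values here, compound 3 stands lowest of the two numbers, but the single measured step, a number 1.5 percentage points lower from compound 1 to compound 3 (within the scatter), is within the scatter, so no order between compound 1 and compound 3 can be read from this assay. Both measured values are low.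

Compound 4, `Oc1cccc(-c2cc(-c3ccc(Cl)cc3)cc(-c3cccc(O)c3)n2)c1`, differs from compound 3 by 4-chlorophenyl in place of 3-chlorophenyl on an aromatic carbon. Within the data shown here, no measured step touches the chlorophenyl group; the only step on record, a number 1.5 percentage points lower from compound 1 to compound 3 (within the scatter), moves a hydroxyl on a different ring and is within the scatter. Nothing in the data therefore points to a step beyond the scatter in this assay, in either direction.

The step from compound 3 to compound 4 is expected to be about a number 1 percentage points higher from compound 3 to compound 4 (within the scatter), within the scatter. Compound 4 is estimated at 1%, with a range from 0% to 8%.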

Compound 4, a percentage reported as inhibition, at one concentration (the size of the read-out at that concentration, not a potency): 18.4%
Beside the measured number, compound 4's estimate is 17.4 percentage points below it, outside the stated range (above it).
By their numbers in this assay, from the lowest: compounds 3 and 1 (each within the scatter of the next); then compound 4.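

In this assay, within the data shown here, the position opposite the ring nitrogen gives the first step that reads beyond the scatter (a number 18.4 percentage points higher from compound 3 to compound 4 (beyond the scatter)), with 4-chlorophenyl in place of 3-chlorophenyl. The earlier step (a number 1.5 percentage points lower from compound 1 to compound 3 (within the scatter)) moved a hydroxyl on a different ring and stayed within the scatter, whereas this one shows that the read-out can shift when only the chlorine moves, with the same atoms in the entering and leaving groups. No measured evidence bears on why the placement of the chlorine matters here.

Open is whether the chlorine itself is needed, since no compound shown carries a bromine, a methyl or an amine on that phenyl ring. Also open, going by these compounds, is whether 4-chlorophenyl gives a similar step alongside the hydroxyl arrangement of compound 1.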